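A Methoxy for Ethyl on the Aniline Ring

The compounds below may be only part of what the source reports. "The series", "measured", "known", "first", "only" and "open" are said of these compounds alone.

Measured in a functional assay on MGC-803 cells (Homo sapiens) for inhibition, read by sulforhodamine B assay; a higher number here means a weaker inhibitor, a lower number a stronger inhibitor:
- compound 1 `O=C1C=C(NCc2ccccc2)C(=O)c2c1nc1n2[C@H]2OC[C@@H](O)[C@H]2OC1`: 2670 nM
- compound 2 `CCc1ccc(NC2=CC(=O)c3c(nc4n3[C@H]3OC[C@@H](O)[C@H]3OC4)C2=O)cc1`: 1110 nM
- compound 3 `O=C1C=C(Nc2cccc(F)c2)C(=O)c2c1nc1n2[C@H]2OC[C@@H](O)[C@H]2OC1`: 2180 nM

Compound 2 gives the lowest number of the three, 1110 nM. That places it within the usual scatter of compound 3 at 2180 nM. Compound 1 gives 2670 nM, and the gap between that value and compound 2 exceeds the usual scatter. The next compound, compound 4 `COc1ccc(NC2=CC(=O)c3c(nc4n3[C@H]3OC[C@@H](O)[C@H]3OC4)C2=O)cc1`, keeps everything in compound 2 except one group, with methoxy in place of ethyl on an aromatic carbon, para to a large group: methoxy in place of ethyl on an aromatic carbon.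

Among the measured compounds shown here, only one measured step offers any guide, and it is not the same change. In this assay, the step of a 1.2-fold lower number from compound 1 to compound 3 (0.09 log units; within the scatter) stays within the scatter, although it replaces the whole group on the amine nitrogen. For the measured compounds named here, no measured pair tests a group at this para place, so the evidence is thin. Going by the values given here, a swap of two small groups is therefore expected to move the number no further than that step did, with no clear direction. The expected change is estimated as a 1.3-fold higher number from compound 2 to compound 4 (0.10 log units; within the scatter), which would not stand beyond the scatter. For compound 4 the estimated value is 1400 nM, with an expected range of 650 nM to 3000 nM.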

Compound 4, half-maximal inhibitory concentration: 2150 nM
Compound 4: middle estimate off by 1.5-fold (0.19 log units), on the low side, within the range that was stated.
By their numbers in this assay, from the lowest: compounds 2, 4, 3 and 1 (each within the scatter of the next, the first and the last beyond it).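

Among the compounds shown here, the first pair that tests this place, an aromatic carbon para to a large group, gives in this assay a 1.9-fold higher number from compound 2 to compound 4 (0.29 log units; within the scatter), so exchanging ethyl for methoxy cannot be read as a real difference between the two compounds. For the compounds shown here, until now, the only measured step had replaced the whole group on the amine nitrogen, whereas this one keeps the count of 2 heavy atoms and leaves that nitrogen and the rest of the molecule untouched, exchanging only a carbon for an oxygen and bringing in 1 hydrogen-bond acceptor where ethyl has none. That exchange leaves the step within the scatter, although no measurement of any property of either group is available to interpret the result.

With only ethyl and methoxy shown at this place, the compounds leave open whether an amine, a carboxylic acid or a longer chain such as butyl would give a number beyond the scatter from these two. They also leave open whether a hydroxyl group, which would bring a hydrogen-bond donor to the same carbon, would behave as methoxy does in this assay.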